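The source may report more compounds than this note shows. Statements on the series, on what has been measured and on what is new or still open speak of the compounds shown alone.

Measured compounds in an assay on Jurkat T cells for inhibition of interleukin-2 (Homo sapiens), read by ELISA, with stated times of 10 min and 24 h; on this read-out lower numbers stand for stronger inhibition and higher numbers for weaker inhibition:
compound 1 `O=C(Nc1ccc(-c2cc(C(F)(F)F)ccc2Cl)cc1)c1c(F)cccc1F`: 8 nM
compound 2 `Cc1ccc(C2=NOC(C)(C)C2=O)cc1-c1cnc(NC(=O)c2c(F)cccc2F)cn1`: 34 nM
compound 3 `CCc1ccc(C2=NOC(C)(C)C2=O)cc1-c1cnc(NC(=O)c2c(F)cccc2F)cn1`: 32 nM

Compound 2 gives the highest of the three numbers in this assay; compound 3 sits within the scatter of it, a 1.1-fold lower number from compound 2 to compound 3 (0.03 log units; within the scatter), while compound 1 lies beyond the scatter with the lower number. The unmeasured compound 4 `Cc1ccc(C2=NOC(C)(C)C2=O)cc1-c1cnc(NC(=O)c2cc(F)ccc2F)cn1` differs from compound 2 by 2,5-difluorophenyl in place of 2,6-difluorophenyl on a carbonyl carbon. No measured step bears on this part of the molecule: the only step shown concerns the methyl on a saturated chain carbon, and every measured compound carries the 2,6-difluorophenyl. No direction can be read from the data, so the range must be wide. Compound 4 is expected near 90 nM, between 25 nM and 350 nM, a step of a 2.6-fold higher number from compound 2 to compound 4 (0.42 log units; beyond the scatter) that is expected to fall close to the scatter.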

Compound 4, half-maximal inhibitory concentration: "not active" (no number reported)
The entry for compound 4 holds no number, and the estimate cannot be compared.
By their numbers in this assay, from the lowest: compound 1; then compounds 3 and 2 (each within the scatter of the next).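

Going by these compounds alone, compound 4 is entered as "not active" with no number in this assay, so no step from compound 2 to compound 4 can be read. The compounds shown leave open how 2,5-difluorophenyl in place of 2,6-difluorophenyl changes the number, and no evidence bears on this result.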